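From ethyl(methyl)amino to diethylamino on the shared core

A few compounds are considered here, and "the series" means these few. Any claim that something is new, unique, unknown or untested is made for them only; others in the source may bear on it.

In a functional assay on HL-60 cells (Homo sapiens) for antiproliferative activity, with a stated time of 72 h (on this read-out lower numbers stand for stronger inhibition and higher numbers for weaker inhibition), compound 1 (`COc1cc(OC)c(C(=O)/C=C/c2ccccc2Cl)c(O)c1CN1CCCC1`), carrying pyrrolidin-1-yl, gives 14200 nM as its number. Compound 2 (`COc1cc(OC)c(C(=O)/C=C/c2ccccc2Cl)c(O)c1CN1CCCCC1`), carrying piperidin-1-yl, gives 3600 nM as its number. Compound 3 (`CCN(C)Cc1c(OC)cc(OC)c(C(=O)/C=C/c2ccccc2Cl)c1O`), carrying ethyl(methyl)amino, gives 200 nM, the lowest of the three numbers.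

Compound 4 (`CCN(CC)Cc1c(OC)cc(OC)c(C(=O)/C=C/c2ccccc2Cl)c1O`) differs from compound 3 by methyl in place of hydrogen on a saturated chain carbon bound to an amine nitrogen, turning ethyl(methyl)amino into diethylamino. Among the compounds with values here, no measured step is this same change. The closest is a 3.9-fold lower number from compound 1 to compound 2 (0.60 log units; beyond the scatter), where pyrrolidin-1-yl gives way to piperidin-1-yl. The other two, a 71-fold lower number from compound 1 to compound 3 (1.85 log units; beyond the scatter) and an 18-fold lower number from compound 2 to compound 3 (1.26 log units; beyond the scatter), exchange the whole amine and show how far the number can move, but they do not fix a direction here. With compound 3 already lowest, a modest rise is expected, though the direction is uncertain. The estimated step is a 2.3-fold higher number from compound 3 to compound 4 (0.35 log units; beyond the scatter) in this series. Compound 4 is expected at 450 nM in this assay, with 120 nM to 2500 nM as the estimated range.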

Compound 4, half-maximal inhibitory concentration: 30900 nM
For compound 4 the middle estimate is 69-fold (1.84 log units) below the measured one, and the stated range ends below it.
By their numbers in this assay, from the lowest: compound 3; then compound 2; then compound 1; then compound 4.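

Adding one methyl to the ethyl(methyl)amino group gives a 150-fold higher number from compound 3 to compound 4 (2.19 log units; beyond the scatter) in this assay and so carries the number across the whole spread of the earlier amines. Diethylamino also sits above both ring amines, with an 8.6-fold higher number from compound 2 to compound 4 (0.93 log units; beyond the scatter) and with a 2.2-fold higher number from compound 1 to compound 4 (0.34 log units; beyond the scatter) as well, so the two open-chain amines lie at opposite ends of the series and the ring amines fall in between. Nothing given here accounts for this sharp difference between two such similar amines.

The compounds shown leave open whether the number at this position climbs steadily with the chain on the nitrogen or whether ethyl(methyl)amino is an isolated low point. Dimethylamino and dipropylamino on the same saturated chain carbon would bear on that question, and morpholin-4-yl would extend the comparison among ring amines.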